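From 4-hydroxyphenyl to 3-methoxyphenyl on a shared core

The source may report more compounds than this note shows. Statements on the series, on what has been measured and on what is new or still open speak of the compounds shown alone.

In a functional assay on MCF7 cells (Homo sapiens) for antiproliferative activity, read by MTT assay, with a stated time of 72 h (on this read-out lower numbers stand for stronger inhibition and higher numbers for weaker inhibition), compound 1 `COc1cc(-n2cnc3ccc(-c4ccc(C(C)=O)cc4)cc32)cc(OC)c1OC` gives 1540 nM, while compound 2 `COc1cc(-n2cnc3ccc(-c4ccc(O)cc4)cc32)cc(OC)c1OC` gives 4160 nM. Compound 2 therefore holds the higher of the two numbers, which means the weaker inhibition of this pair. Compound 3 `COc1cccc(-c2ccc3ncn(-c4cc(OC)c(OC)c(OC)c4)c3c2)c1` has not yet been measured. It carries 3-methoxyphenyl in place of 4-hydroxyphenyl on an aromatic carbon of the shared core: 3-methoxyphenyl in place of 4-hydroxyphenyl on an aromatic carbon. Among the measured compounds shown here, only one measured step bears on this change, and it does so indirectly. For the measured compounds named here, replacing acetyl with hydroxy gave a 2.7-fold higher number from compound 1 to compound 2 (0.43 log units; beyond the scatter), a modest step beyond the scatter, so the one compound with hydroxy is the one with the higher number. Going by the values given here, compound 3 also lacks hydroxy, but its group differs from the acetyl of compound 1, and no measured compound shows the effect of a methoxy group here. A small move towards a lower number is therefore expected, and it may not clear the scatter. The expected step is a 1.7-fold lower number from compound 2 to compound 3 (0.22 log units; within the scatter). Compound 3 is estimated at 2500 nM, with an expected range from 900 nM to 7000 nM.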

Compound 3, half-maximal inhibitory concentration: 1610 nM
For compound 3 the middle estimate is 1.6-fold (0.19 log units) above the measured one; the range from low to high includes it.
By their numbers in this assay, from the lowest: compounds 1 and 3 (each within the scatter of the next); then compound 2.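

In this assay, among the compounds shown here, the change from 4-hydroxyphenyl to 3-methoxyphenyl gives a 2.6-fold lower number from compound 2 to compound 3 (0.41 log units; beyond the scatter), so a second group without hydroxy now separates from compound 2 by more than the scatter, and this position has a measured methoxy-bearing ring for the first time. Exchanging 4-acetylphenyl for 3-methoxyphenyl gives a 1.0-fold higher number from compound 1 to compound 3 (0.02 log units; within the scatter), which places two different groups on the same level at this aromatic carbon and leaves compound 2, the only one of the three with hydroxy, as the weakest inhibitor. Nothing in the material shown explains why these two groups match or why the 4-hydroxyphenyl compound stands apart.

The step from compound 2 to compound 3 alters both the substituent and its place on the phenyl ring, so the contribution of each remains unresolved, and 3-hydroxyphenyl and 4-methoxyphenyl would be the groups needed to separate them. It also remains open how this position would respond to a phenyl ring carrying an amine or a carboxylic acid, since all three groups shown are neutral.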